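The compounds below may be only part of what the source reports. "The series", "measured", "known", "first", "only" and "open" are said of these compounds alone.

Measured in an ADME assay on A549 cells (Homo sapiens) for cytotoxicity, read by resazurin assay, with a stated time of 48 h; on this read-out lower numbers stand for higher toxicity in this test and higher numbers for lower toxicity in this test:
- compound 1 `O=C(Nc1ccc(NC2CCCCC2)cc1Cl)c1cc(Cl)ccc1O`: 68300 nM
- compound 2 `CCCN(CCC)c1ccc(NC(=O)c2cc(Cl)ccc2O)c(Cl)c1`: 10700 nM
- compound 3 `O=C(Nc1ccc(NCc2ccc(F)cc2)cc1Cl)c1cc(Cl)ccc1O`: 54400 nM

With 54400 nM, compound 3 belongs to the upper pair of these three numbers. It is close to one neighbour, a 1.3-fold lower number from compound 1 to compound 3 (0.10 log units; within the scatter), and clearly apart from the other, a 5.1-fold higher number from compound 2 to compound 3 (0.71 log units; beyond the scatter).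

The next molecule, compound 4 `O=C(Nc1ccc(NCc2ccc(Cl)cc2)cc1Cl)c1cc(Cl)ccc1O`, changes one atom: chloro in place of fluoro on an aromatic carbon. This puts chloro in place of fluoro on an aromatic carbon, para to a large group.

For the measured compounds named here, no measured step makes this exact swap, so the evidence is indirect. The two larger steps, a 6.4-fold lower number from compound 1 to compound 2 (0.81 log units; beyond the scatter) and a 5.1-fold higher number from compound 2 to compound 3 (0.71 log units; beyond the scatter), both involve the dipropylamino group of compound 2, which compound 4 does not carry. The closest guide is a 1.3-fold lower number from compound 1 to compound 3 (0.10 log units; within the scatter), where replacing a whole group left the number within the scatter. A single halogen swap is a much smaller edit, so no change beyond the scatter is expected in this assay.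

The expected step is a 1.2-fold lower number from compound 3 to compound 4 (0.08 log units; within the scatter). For compound 4 the estimate is 45000 nM, with an expected range of 20000 nM to 95000 nM.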

Compound 4, half-maximal cytotoxic concentration: 59700 nM
Compound 4: the middle estimate sits 1.3-fold (0.12 log units) below what was measured; the measured number falls inside the stated range.
By their numbers in this assay, from the lowest: compound 2; then compounds 3, 4 and 1 (each within the scatter of the next).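

For the compounds shown here, this is the first direct read of the halogen on the benzyl ring: in this assay, chloro in place of fluoro on this aromatic carbon, para to a large group, gives a 1.1-fold higher number from compound 3 to compound 4 (0.04 log units; within the scatter) and so leaves the number within the scatter. The 4-chlorobenzyl group also stays close to cyclohexyl on the nitrogen (a 1.1-fold lower number from compound 1 to compound 4 (0.06 log units; within the scatter)), whereas the change from dipropylamino gives a step beyond the scatter (a 5.6-fold higher number from compound 2 to compound 4 (0.75 log units; beyond the scatter)), so the larger difference still goes with compound 2 alone. No measurement is available to explain why the halogen swap leaves the number so little changed.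

Whether this position accepts other groups equally well remains open, since only two halogens are shown there. A bromo, a methoxy group, a carboxylic acid or an amine on the same carbon might give a quite different number.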